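The source may report more compounds than this note shows. Statements on the series, on what has been measured and on what is new or still open speak of the compounds shown alone.

Measured compounds:
- compound 1 `COc1cc(/C=C/C(=O)c2cccc(-n3cc(-c4ccc(Cl)cc4)[nH]c3=O)c2)cc(OC)c1OC`: 3220 nM
- compound 2 `O=C(/C=C/c1cccc(O)c1)c1cccc(-n2cc(-c3ccc(Cl)cc3)[nH]c2=O)c1`: 1510 nM

Both compounds were tested in a functional assay on RXF 393 cells (Homo sapiens) for inhibition; a lower number here means a stronger inhibitor of growth, a higher number a weaker inhibitor of growth. Compound 1 gives 3220 nM, the higher of the two numbers, so it is the weaker growth inhibitor of this pair. Compound 2 gives 1510 nM in this assay, and the gap between the two lies beyond the usual scatter, so compound 2 is the stronger of the two. The two differ in more than one place, so no single change can be credited with that gap.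

Compound 3 `COc1cc(/C=C/C(=O)c2cccc(-n3cc(-c4cc(OC)c(OC)c(OC)c4)[nH]c3=O)c2)cc(OC)c1OC` has not yet been measured. It differs from compound 1 in one place: 3,4,5-trimethoxyphenyl in place of 4-chlorophenyl on an aromatic carbon. Among the measured compounds shown here, no measured pair shows this exact change, so there is no direct precedent to lean on. With only two measured points, a step of either direction is plausible; the expected step from compound 1 to compound 3 is a 1.1-fold higher number from compound 1 to compound 3 (0.04 log units; within the scatter), which is essentially no change beyond the scatter, with wide uncertainty. For compound 3 the estimated result in this assay is 3500 nM, within a range from 1000 nM to 12000 nM.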

Compound 3, concentration for 50% growth inhibition: 1620 nM
Estimate against measurement, compound 3: 2.2-fold (0.33 log units) above; measured number inside the range.
By their numbers in this assay, from the lowest: compounds 2, 3 and 1 (each within the scatter of the next, the first and the last beyond it).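

Replacing 4-chlorophenyl with 3,4,5-trimethoxyphenyl on this aromatic carbon gives a 2.0-fold lower number from compound 1 to compound 3 (0.30 log units; within the scatter) in this assay, so this pair shows no real difference in growth inhibition. Among the compounds shown here, the new information is that this place can hold a much larger group, with 12 heavy atoms instead of 7 and 3 hydrogen-bond acceptors instead of 0, while the number stays within the scatter of the one for compound 1. No measurement is available to explain why the two groups give such similar numbers.

Still open, on these data alone, is whether this place accepts any group at all or only a six-membered aromatic ring of carbon, and a methyl, an unsubstituted phenyl or a phenyl carrying a carboxylic acid or an amine would each test that further. As far as these compounds go, it is also open whether the same exchange would give a similar result on compound 2, which differs from compound 1 in more than one place and therefore cannot yet be linked to this step.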